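The source may report more compounds than this note shows. Statements on the series, on what has been measured and on what is new or still open speak of the compounds shown alone.

In a functional assay on HT-1080 cells (Homo sapiens) for antiproliferative activity, read by MTT assay, with a stated time of 72 h (a lower number here means a stronger inhibitor, a higher number a weaker inhibitor), compound 1 `CCOC(=O)c1cc(-c2cc(OC)c(OC)c(OC)c2)c(-c2ccc3ccccc3c2)s1` gives 1150 nM. Compound 2 `CCOC(=O)c1cc(-c2cc(OC)c(OC)c(OC)c2)c(-c2ccc(OC)c(OCc3ccccc3)c2)s1` gives only a limit of the assay, > 100000 nM. Compound 3 `CCOC(=O)c1cc(-c2cc(OC)c(OC)c(OC)c2)c(-c2ccc(OC)c(O)c2)s1` gives 3220 nM, the higher of the two actual numbers in the series. Placing 3-hydroxy-4-methoxyphenyl where naphthalen-2-yl stood produced a 2.8-fold higher number from compound 1 to compound 3 (0.45 log units; beyond the scatter), a modest step. Placing hydrogen where benzyl stood on an oxygen on an aromatic ring produced an at least 31-fold lower number from compound 2 to compound 3 (1.49 log units; beyond the scatter), a large step.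

Compound 4 `COc1ccc(-c2sccc2-c2cc(OC)c(OC)c(OC)c2)cc1O` now carries hydrogen in place of ethoxycarbonyl on an aromatic carbon. Neither measured step touches this place, so both bear on it only indirectly. For the measured compounds named here, the closest guide is the one step that strips a group away, an at least 31-fold lower number from compound 2 to compound 3 (1.49 log units; beyond the scatter), although it acts elsewhere on the molecule. A modest improvement is therefore expected, with low confidence in its size and direction: a 3.2-fold lower number from compound 3 to compound 4 (0.51 log units; beyond the scatter). For compound 4 the estimated value is 1000 nM, with an expected range of 60 nM to 15000 nM.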

Compound 4, half-maximal inhibitory concentration: 1940 nM
Compound 4: middle estimate off by 1.9-fold (0.29 log units), on the low side; the measured number falls inside the stated range.
By their numbers in this assay, from the lowest: compounds 1, 4 and 3 (each within the scatter of the next, the first and the last beyond it). At a limit, above all of these: compound 2.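

Hydrogen in place of ethoxycarbonyl, on the aromatic carbon next to the ring sulfur, gives a 1.7-fold lower number from compound 3 to compound 4 (0.22 log units; within the scatter) in this assay. For the compounds shown here, all the earlier compounds carry the ethoxycarbonyl group, so they could not show that antiproliferative activity on these cells persists without it; with the whole group gone, compound 4 still reads as compound 3 does within the scatter. Nothing among the data shown explains this result.

Going by these compounds, only ethoxycarbonyl and hydrogen are seen at this place, so it remains open how a carboxylic acid, a primary amide or an aminomethyl group there would read. On these data alone, it is also open whether the same exchange would leave the number as little moved with the naphthalen-2-yl group of compound 1 in place of the 3-hydroxy-4-methoxyphenyl group.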